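Cyanoguanidine side chain: from branched alkyl to phenylethyl

The source may hold more compounds than are shown below. What is called first, only, known or untested is meant among the compounds shown, and "the series" means these compounds.

The measured compounds, all sharing one core, were:
compound 1, `CC(C)(C)C/N=C(\NC#N)Nc1ccncc1`: 5 mg/kg
compound 2, `CC(C)CC(C)/N=C(\NC#N)Nc1ccncc1`: 35 mg/kg
compound 3, `N#CN/C(=N\C1CCCCC1)Nc1ccncc1`: 20 mg/kg

These three were tested in a functional assay on the whole organism (blood, strain Wistar-Okamoto) with Rattus norvegicus as the target, with a stated time of 5 days; a lower number here means that less compound is needed, a higher number that more compound is needed for the effect. Compound 2 gives the highest number of the three; compound 3 lies close to it, the pair differing by a 1.8-fold lower number from compound 2 to compound 3 (0.24 log units; within the scatter), while compound 1 stands furthest away, at a 7.0-fold higher number from compound 1 to compound 2 (0.85 log units; beyond the scatter).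

The next compound, compound 4, `CC(/N=C(\NC#N)Nc1ccncc1)c1ccccc1`, has not yet been measured. It differs from compound 2 in one place: phenyl in place of isobutyl on a saturated chain carbon bound to a double-bonded nitrogen and a saturated chain carbon.

Among the measured compounds shown here, no measured step exchanges an alkyl for an aromatic group on this chain. What the data do show is that the group on the double-bonded nitrogen matters: a 7.0-fold higher number from compound 1 to compound 2 (0.85 log units; beyond the scatter) and a 4.0-fold higher number from compound 1 to compound 3 (0.60 log units; beyond the scatter) are both beyond the scatter, whereas a 1.8-fold lower number from compound 2 to compound 3 (0.24 log units; within the scatter) is not. Compound 2 sitting at the top leaves room for a lower number, and a change of this size on the chain could plausibly give one, but a step within the scatter cannot be excluded.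

Compound 4 is therefore expected to give about 20 mg/kg, within 7 mg/kg to 60 mg/kg. That estimate for compound 4 corresponds to an expected 1.8-fold lower number from compound 2 to compound 4 (0.24 log units; within the scatter).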

Compound 4, minimum effective dose: 10 mg/kg
The estimate for compound 4 lay 2.0-fold (0.30 log units) above the measured number; the measured number falls inside the stated range.
By their numbers in this assay, from the lowest: compounds 1, 4, 3 and 2 (each within the scatter of the next, the first and the last beyond it).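

Among the compounds shown here, the exchange of isobutyl for phenyl is the first alkyl-to-aromatic step, and in this assay it gives a 3.5-fold lower number from compound 2 to compound 4 (0.54 log units; beyond the scatter). The earlier steps shown here varied only saturated groups on the double-bonded nitrogen, whereas this one shows that a six-membered aromatic ring of carbon only is compatible with the effect on a saturated chain carbon bound to a double-bonded nitrogen and a saturated chain carbon, and that the number moves down with it. Nothing given here accounts for this step, so it stands as an observation without an explanation.

The compounds shown leave open whether the lower number needs the aromatic ring itself, since a cyclohexyl group at this same place would separate the ring's aromatic character from its mere presence. They also leave open how a chloro or methoxy group on the phenyl ring, a pyridyl ring in its stead, or a longer chain joining the phenyl to the double-bonded nitrogen would alter the number.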